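The source may report more compounds than this note shows. Statements on the series, on what has been measured and on what is new or still open speak of the compounds shown alone.

Measured compounds:
Compound 1 `CN(C)C(=O)c1cc2cnc(Nc3ccc(NC(=O)C4(C(=O)Nc5cccc(O)c5)CC4)cc3)nc2n1C1CCCC1` gives 80.7% in a functional assay on T47D cells (Homo sapiens) for inhibition, read by CCK-8 assay, with a stated time of 72 h, tested at 1 uM; on this read-out lower numbers stand for less inhibition of growth and higher numbers for more inhibition of growth at the one concentration tested.
Compound 2 `CN(C)C(=O)c1cc2cnc(Nc3ccc(NC(=O)C4(C(=O)Nc5ccc(F)cc5)CC4)cc3F)nc2n1C1CCCC1` gives 6.3% in this assay.
Compound 3 `CN(C)C(=O)c1cc2cnc(Nc3ccc(NC(=O)C4(C(=O)Nc5ccc(Cl)c(C(F)(F)F)c5)CC4)cc3)nc2n1C1CCCC1` gives 6.9% in this assay.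

Compound 1 stands highest of the three numbers in this assay; compound 3 is nearest and compound 2 furthest, both far beyond the scatter. Compound 4 `CN(C)C(=O)c1cc2cnc(Nc3ccc(NC(=O)C4(C(=O)Nc5cccc(Cl)c5)CC4)cc3)nc2n1C1CCCC1` has not yet been measured. It differs from compound 1 in one place: chloro in place of hydroxy on an aromatic carbon. The step that bears most directly on this change is the one in which the same 3-hydroxyphenyl group was exchanged for a different halogenated phenyl group, and that step read a number 73.8 percentage points lower from compound 1 to compound 3 (beyond the scatter). Among the compounds with values here, compound 2, carrying a 4-fluorophenyl group and a further ring fluorine, likewise lies far below compound 1, though no single-place step connects the two. Both halogenated phenyl amides fell to a small fraction of the growth inhibition of compound 1, so a large downward step is expected for a number 60.7 percentage points lower from compound 1 to compound 4 (beyond the scatter). Compound 4 is therefore estimated at 20%, with a range from 5% to 55%.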

Compound 4, percent growth inhibition at one concentration: 39.3%
Compound 4: the middle estimate sits 19.3 percentage points below what was measured; the measured number falls inside the stated range.
By their numbers in this assay, from the lowest: compounds 2 and 3 (each within the scatter of the next); then compound 4; then compound 1.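

In this assay, the change from 3-hydroxyphenyl to 3-chlorophenyl gives a number 41.4 percentage points lower from compound 1 to compound 4 (beyond the scatter) and so lowers growth inhibition without removing it, a distinction that the larger exchange in compound 3 could not make. The 3-chlorophenyl group also separates from the 4-chloro-3-(trifluoromethyl)phenyl group, with a number 32.4 percentage points higher from compound 3 to compound 4 (beyond the scatter) on that exchange, so the halogenated phenyl amides in this single-place comparison do not all fall equally far. Nothing given here explains either step.

Going by these compounds, it remains open whether an amino, methoxy or carboxylic acid group at this place would stand nearer compound 1 or compound 4. On these data alone, it is also open whether chloro elsewhere on this phenyl ring, without trifluoromethyl, would read like compound 3 or like compound 4.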